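Methyl on the Exocyclic Amine of a Bisphosphate Antagonist

The source may hold more compounds than are shown below. What is called first, only, known or untested is meant among the compounds shown, and "the series" means these compounds.

Of the compounds shown here, two sharing a deoxyribose bisphosphate core have so far been measured in a functional assay for antagonist activity at P2Y purinoceptor 1 (Meleagris gallopavo); a higher number here means a weaker inhibitor, a lower number a stronger inhibitor. Compound 1 `CSc1ncnc2c1ncn2[C@H]1C[C@H](OP(=O)(O)O)[C@@H](COP(=O)(O)O)O1` gives 29100 nM in this assay. Compound 2 `Nc1ncnc2c1ncn2C1OC(COP(=O)(O)O)CC1OP(=O)(O)O` gives 11000 nM in this assay, the lower of the two numbers, and its distance from compound 1 lies beyond the usual scatter, so compound 2 is the stronger inhibitor of the pair.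

Compound 3 `CNc1ncnc2c1ncn2C1OC(COP(=O)(O)O)CC1OP(=O)(O)O` has not yet been measured. The difference from compound 2 is small on paper: methyl in place of hydrogen on a nitrogen on an aromatic ring. Within the data shown here, no pair of measured compounds shows this particular change, so its size cannot be read from a direct precedent; the one step seen, from the methylthio compound to the amino compound, concerns a different position.

For compound 3 the expected step from a 7.3-fold lower number from compound 2 to compound 3 (0.87 log units; beyond the scatter) is a clear gain in potency, beyond the scatter. Compound 3 is therefore estimated at 1500 nM in this assay, with a plausible range from 300 nM to 7000 nM.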

Compound 3, half-maximal inhibitory concentration: 324 nM
For compound 3 the middle estimate is 4.6-fold (0.67 log units) above the measured one; measured number inside the range.
By their numbers in this assay, from the lowest: compound 3; then compound 2; then compound 1.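

Replacing amino with methylamino gives a 34-fold lower number from compound 2 to compound 3 (1.53 log units; beyond the scatter) in this assay, so one added methyl on a nitrogen on an aromatic ring is enough to produce a large change in this series. Compound 1 and compound 2 differ in more than one place, so they could not show what this nitrogen substituent contributes. The new pair gives the first direct reading. Only this hydrogen and methyl differ between the two structures. Nothing shown gives a measured reason for the size of this step.

The step rests on a single pair, so it does not show whether a longer chain on the same nitrogen, such as ethylamino or propylamino, or a dimethylamino group would extend the gain, hold it or lose it. It also leaves open whether methylamino would bring a step of similar size on the core of compound 1, where the phosphate groups are arranged differently from those of compound 2 and compound 3.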